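A few compounds are considered here, and "the series" means these few. Any claim that something is new, unique, unknown or untested is made for them only; others in the source may bear on it.

Measured compounds in this series:
- compound 1 `O=C(NCc1ccc(S(=O)(=O)C2CCC(F)(F)CC2)cc1)N1Cc2ccncc2C1`: 13 nM
- compound 2 `CCC(=O)N1CCC(S(=O)(=O)c2ccc(CNC(=O)N3Cc4ccncc4C3)cc2)CC1`: 54 nM
- compound 3 `O=C(NCc1ccc(S(=O)(=O)C2CCN(C3COC3)CC2)cc1)N1Cc2ccncc2C1`: 7.4 nM

In a functional assay on A2780 cells (Homo sapiens) for cytotoxicity, read by sulforhodamine B assay, with a stated time of 72 h (on this read-out higher numbers stand for weaker inhibition and lower numbers for stronger inhibition), compound 1 stands second highest of the three numbers, with compound 3 nearest and compound 2 furthest. The steps from compound 1 describe two exchanges on the sulfonyl sulfur: a 4.2-fold higher number from compound 1 to compound 2 (0.62 log units; beyond the scatter), whereas a 1.8-fold lower number from compound 1 to compound 3 (0.24 log units; within the scatter). Directly, a 7.3-fold lower number from compound 2 to compound 3 (0.86 log units; beyond the scatter).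

Compound 4 `O=C(NCc1ccc(S(=O)(=O)N2CCC(N3CCCC3)CC2)cc1)N1Cc2ccncc2C1` is not yet measured. Relative to compound 1 the change is 4-(pyrrolidin-1-yl)piperidin-1-yl in place of 4,4-difluorocyclohexyl on a sulfonyl sulfur. The entering group resembles compound 3 rather than compound 2 in that its piperidine nitrogen bears a second ring rather than a propanoyl, and it brings one hydrogen-bond acceptor. Within the data shown here, the step from compound 1 to compound 3 was within the scatter, and the step from compound 1 to compound 2 was modest; no measured compound places a nitrogen on the sulfonyl sulfur, so the sulfonamide linkage itself has no precedent here. The expectation for compound 4 is therefore a step of a 1.1-fold lower number from compound 1 to compound 4 (0.03 log units; within the scatter), small and within the scatter. Compound 4 is estimated at 12 nM, expected between 4 nM and 40 nM.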

Compound 4, half-maximal inhibitory concentration: 5.6 nM
Estimate against measurement, compound 4: 2.1-fold (0.33 log units) above; the range from low to high includes it.
By their numbers in this assay, from the lowest: compounds 4, 3 and 1 (each within the scatter of the next, the first and the last beyond it); then compound 2.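

Among these compounds, on the sulfonyl sulfur, a group attached through a ring nitrogen is accepted in this assay: a 2.3-fold lower number from compound 1 to compound 4 (0.37 log units; beyond the scatter), the only step away from the 4,4-difluorocyclohexyl group that gives a lower number beyond the scatter. Among the compounds shown here, the 4-(pyrrolidin-1-yl)piperidin-1-yl and 1-(oxetan-3-yl)piperidin-4-yl groups cannot be told apart (a 1.3-fold lower number from compound 3 to compound 4 (0.12 log units; within the scatter)), whereas the 1-propanoylpiperidin-4-yl group stands clearly apart (a 9.6-fold lower number from compound 2 to compound 4 (0.98 log units; beyond the scatter)), the largest step so far. No measurement shown here bears on the origin of these steps.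

The compounds shown do not separate the contribution of the ring nitrogen on sulfur from that of the pyrrolidine ring. An unsubstituted piperidin-1-yl or a morpholin-4-yl on the sulfonyl sulfur, or a dimethylamino group in place of the pyrrolidin-1-yl, would address this.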